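This account rests on a few compounds, and the source may have more. Where it says the series, first, only, none or still open, it means among the compounds named here.

Of the compounds shown here, three have been measured in a functional assay on CCRF-CEM cells (Homo sapiens); a lower number here means that less compound is tolerated, a higher number that more compound is tolerated. Compound 1 `Cc1cn([C@@H]2O[C@@H]3COC4(O)CS(=O)(=O)O[C@@]34[C@H]2O)c(=O)[nH]c1=O` gives 100000 nM, and compound 3 `Cc1cn([C@@H]2O[C@@H]3COC4(O)CS(=O)(=O)O[C@@]34[C@H]2O[Si](C)(C)C(C)(C)C)c(=O)[nH]c1=O` gives 100000 nM in this assay. Within the data shown here, the only measured step that changes one place, no change at the digits printed from compound 1 to compound 3 (within the scatter), is a group of seven heavy atoms in place of a hydrogen on an oxygen of a saturated carbon, and it leaves the number where it was. Compound 2 `COC(=O)CC(=O)NC1=CS(=O)(=O)O[C@@]12[C@@H](CO[Si](C)(C)C(C)(C)C)O[C@@H](n1cc(C)c(=O)n(C)c1=O)[C@@H]2O[Si](C)(C)C(C)(C)C` gives 29700 nM in this assay, the lowest of the three numbers, with both other compounds beyond the scatter from it.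

Compound 4 `CCNC(=O)NC1=CS(=O)(=O)O[C@@]12[C@@H](CO[Si](C)(C)C(C)(C)C)O[C@@H](n1cc(C)c(=O)n(C)c1=O)[C@@H]2O[Si](C)(C)C(C)(C)C` differs from compound 2 by ethylamino in place of (methoxycarbonyl)methyl on a carbonyl carbon. Among the measured compounds shown here, no measured step touches this carbonyl carbon or its amide-type nitrogen, so the one step that is known does not bear on the change. With nothing to point either way, no step beyond the scatter is expected in this assay. The step expected is therefore a 1.0-fold higher number from compound 2 to compound 4 (0.00 log units; within the scatter), within the scatter. Compound 4 is estimated at 30000 nM, expected to fall between 10000 nM and 100000 nM.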

Compound 4, half-maximal cytotoxic concentration: 4260 nM
Estimate against measurement, compound 4: 7.0-fold (0.85 log units) above; measured number outside the range, below it.
By their numbers in this assay, from the lowest: compound 4; then compound 2; then compounds 1 and 3 (each within the scatter of the next).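

In this assay, among these compounds, the group on this carbonyl carbon matters: ethylamino in place of (methoxycarbonyl)methyl gives a 7.0-fold lower number from compound 2 to compound 4 (0.84 log units; beyond the scatter) and is the first single change to go beyond the scatter. Among the compounds shown here, the only earlier step, no change at the digits printed from compound 1 to compound 3 (within the scatter) on an oxygen on a saturated carbon, left the number where it was and said nothing about this carbonyl carbon. Nothing available explains the shift.

The compounds shown leave open whether the lower number follows from the ethylamino group itself or from the loss of the methyl ester. They also leave open what a longer chain such as butylamino, or a carboxylic acid in place of the ester, would do on this carbonyl carbon.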